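The compounds below may be only part of what the source reports. "The series", "measured", "known", "first", "only" and "open" are said of these compounds alone.

Compound 2 `O=C(Nc1cccc(F)c1)c1cc(=O)[nH]c2cc(Br)ccc12` is the only one of the three measured compounds for which a number, rather than a limit, is available: in a functional assay on KYSE-70 cells for antiproliferative activity against KYSE-70 cell line (Homo sapiens), read by MTT assay, with a stated time of 72 h (a lower number here means a stronger inhibitor, a higher number a weaker inhibitor), compound 2 gives 8900 nM. Compound 1 `O=C(Nc1cc(F)ccc1F)c1cc(=O)[nH]c2cc(Br)ccc12` gives only a limit, > 20000 nM. Compound 3 `O=C(Nc1cccc(Cl)c1)c1cc(=O)[nH]c2cc(Br)ccc12` likewise gives only a limit, > 20000 nM. Compound 4 `O=C(Nc1cccc(F)c1)c1cc(=O)[nH]c2cc(C3=CCOCC3)ccc12` differs from compound 2 by a group of 6 heavy atoms (5 carbon, 1 oxygen; one six-membered non-aromatic ring with 1 hetero atom) in place of one bromine atom, on an aromatic carbon. The two measured steps, an at least 2.2-fold lower number from compound 1 to compound 2 (0.35 log units; beyond the scatter) and an at least 2.2-fold higher number from compound 2 to compound 3 (0.35 log units; beyond the scatter), both alter a different part of the molecule from the one changed here, so neither bears directly on this change, and the limit of > 20000 nM in this assay, at which 2 of the 3 values shown sit, leaves even their own sizes open. Going by the values given here, with no measured step at this position, the expected step is a 1.5-fold lower number from compound 2 to compound 4 (0.17 log units; within the scatter), with wide uncertainty. Compound 4 is therefore estimated at 6000 nM, with a range from 1500 nM to 20000 nM.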

Compound 4, half-maximal inhibitory concentration: 10500 nM
Compound 4: middle estimate off by 1.8-fold (0.24 log units), on the low side, and the stated range covers the measured number.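

In this assay, the change gives a 1.2-fold higher number from compound 2 to compound 4 (0.07 log units; within the scatter), so this aromatic carbon takes a six-membered non-aromatic ring of 6 heavy atoms in place of a single bromine atom with no change beyond the scatter. Going by these compounds alone, the earlier steps altered only fluoro and chloro groups elsewhere in the molecule, so this is the first reading at this position. Nothing shown accounts for why the number holds. On these data alone, whether an amine or a carboxylic acid on this carbon would behave the same stays open, as does whether the ring oxygen or the double bond matters.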